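A few compounds are considered here, and "the series" means these few. Any claim that something is new, unique, unknown or untested is made for them only; others in the source may bear on it.

Measured so far in a functional assay on cells (leukaemia cell line, Homo sapiens) for inhibition, read by sulforhodamine B assay, with a stated time of 48 h; a lower number here means a stronger inhibitor of growth, a higher number a weaker inhibitor of growth:
Compound 1 `O=S(=O)(Nc1ccccc1Cl)c1ccc(-c2cnc(C3CC3)o2)cc1`: 49700 nM
Compound 2 `Cc1cc(NS(=O)(=O)c2ccc(-c3cnc(C4CC4)o3)cc2)ccc1Cl`: 33400 nM

Within the data shown here, only two compounds have numbers, and they cannot be told apart. Among the measured compounds shown here, the one measured step, a 1.5-fold lower number from compound 1 to compound 2 (0.17 log units; within the scatter), leaves the two level, with compound 2 at 33400 nM.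

Compound 3 `Cc1ccc(NS(=O)(=O)c2ccc(-c3cnc(C4CC4)o3)cc2)cc1C` keeps the shared core and the sulfonamide and alters a single group. The change is methyl in place of chloro on an aromatic carbon, ortho to a methyl group and para to a large group, so that 4-chloro-3-methylphenyl becomes 3,4-dimethylphenyl.

For the measured compounds named here, no measured step makes this exact swap, so the evidence is indirect. The nearest guide is a 1.5-fold lower number from compound 1 to compound 2 (0.17 log units; within the scatter), where the whole group on the sulfonamide nitrogen was replaced and the numbers still stayed within the scatter. A smaller edit at one position is therefore expected to produce no step beyond the scatter in this assay, in either direction. The estimated outcome is a 1.0-fold higher number from compound 2 to compound 3 (0.02 log units; within the scatter). Compound 3 is expected at about 35000 nM, with an estimated range from 17000 nM to 70000 nM.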

Compound 3, concentration for total growth inhibition: > 100000 nM
Compound 3: only a limit was reported; the forecaster's own chance of this, stated with the estimate: 10%; middle value at least 2.8-fold (0.45 log units) from the limit.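

In this assay compound 3 carries only a limit of the assay, not a number: the limit of > 100000 nM in this assay, at which 1 of the 3 values shown sits.

Even so, exchanging a single group at this position, methyl in place of chloro, gives an at least 2.9-fold higher number from compound 2 to compound 3 (0.47 log units; beyond the scatter), the first step in this small set that lies beyond the scatter, so this carbon of the ring on the sulfonamide nitrogen is not indifferent to what it carries, which the earlier pair could not show. Among these compounds, the comparison with the other chlorinated compound, where the whole group on the sulfonamide nitrogen differs, gives an at least 2.0-fold higher number from compound 1 to compound 3 (0.30 log units; that floor lies within the scatter), and that floor stays within the scatter, so the firm separation holds only for the single swap from compound 2.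

The compounds shown leave open how large the step from compound 2 really is, and whether chloro is special at this carbon or methyl alone is the exception. A fluoro group, a methoxy group or an amine on the same carbon would show whether the number stays close to that of compound 2 or moves towards the limit of compound 3.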